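From 3-chlorophenyl to 4-fluorophenyl on an amine nitrogen

This account rests on a few compounds, and the source may have more. Where it says the series, first, only, none or still open, it means among the compounds named here.

Of the compounds shown here, three sharing one core have been measured in a functional assay on MDA-MB-231 cells (Homo sapiens) for antiproliferative activity, read by MTT assay, with a stated time of 24 h; a lower number here means a stronger inhibitor, a higher number a weaker inhibitor: compound 1 (`Cc1ccccc1NNC(=O)c1ccc(NS(=O)(=O)c2cnc(O)nc2O)cc1`), compound 2 (`O=C(NNc1ccccc1Cl)c1ccc(NS(=O)(=O)c2cnc(O)nc2O)cc1`) and compound 3 (`O=C(NNc1cccc(Cl)c1)c1ccc(NS(=O)(=O)c2cnc(O)nc2O)cc1`). Compound 1 reaches only a limit of the assay, > 20000 nM. Compound 2 gives 4010 nM. Compound 3 gives 17400 nM, the higher of the two actual numbers.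

The next compound, compound 4 (`O=C(NNc1ccc(F)cc1)c1ccc(NS(=O)(=O)c2cnc(O)nc2O)cc1`), carries 4-fluorophenyl in place of 3-chlorophenyl on an amine nitrogen. The nearest measured precedent is a 4.3-fold higher number from compound 2 to compound 3 (0.64 log units; beyond the scatter), where 3-chlorophenyl replaces 2-chlorophenyl on an amine nitrogen. A step of similar size appears in an at least 4.9-fold lower number from compound 1 to compound 2 (0.69 log units; beyond the scatter), with chloro in place of methyl on an aromatic carbon. By contrast, an at least 1.1-fold lower number from compound 1 to compound 3 (0.06 log units; that floor lies within the scatter) shows no change beyond the scatter. For the measured compounds named here, both steps beyond the scatter involve compound 2, and no measured compound carries a fluoro group. Compound 4 is therefore expected to stay near compound 3 at 17400 nM rather than approach compound 2. The expected change is small and within the scatter, slightly downward: a 1.5-fold lower number from compound 3 to compound 4 (0.16 log units; within the scatter). For compound 4 the estimated value in this assay is 12000 nM, with an expected range from 5000 nM to 28000 nM.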

Compound 4, half-maximal inhibitory concentration: > 20000 nM
Compound 4: only a limit was reported; the forecaster's own chance of this, stated with the estimate: 25%; middle value at least 1.6-fold (0.22 log units) from the limit.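

In this assay, the change to 4-fluorophenyl on an amine nitrogen gives an at least 1.1-fold higher number from compound 3 to compound 4 (0.06 log units; that floor lies within the scatter), and that floor alone does not separate the two compounds. The comparison with compound 2 is clearer, with an at least 4.9-fold higher number from compound 2 to compound 4 (0.69 log units; beyond the scatter), so this first fluoro group at the position does not bring the compound close to the 2-chlorophenyl result, and compound 2 now stands apart from all three other compounds by steps beyond the scatter. The step between compound 1 and compound 4 cannot be read, since both values are limits: the limit of > 20000 nM in this assay, at which 2 of the 4 values shown sit.

The move from 3-chlorophenyl to 4-fluorophenyl changes the halogen and its place on the ring together, so the compounds shown cannot divide the outcome between those two changes; 4-chlorophenyl and 2-fluorophenyl would be the groups that separate them. Also open, going by these compounds, is how this position responds to groups of another kind on the phenyl ring, such as a methoxy group, a nitrile or a carboxylic acid.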